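This account rests on a few compounds, and the source may have more. Where it says the series, first, only, none or still open, it means among the compounds named here.

Compound 2 `O=C1C=C(NC2CCCCC2)C(=O)c2c1nc1n2[C@H]2OC[C@@H](O)[C@H]2OC1` carries a cyclohexylamino group on the shared core. In a functional assay on MCF7 cells (Homo sapiens) for inhibition, read by sulforhodamine B assay (on this read-out lower numbers stand for stronger inhibition and higher numbers for weaker inhibition), compound 2 gives no number, only the limit of the assay, > 8000 nM. Compound 1 `O=C1C(Nc2ccccc2)=CC(=O)c2c1nc1n2[C@H]2OC[C@@H](O)[C@H]2OC1` carries a phenylamino group on the same core. In this assay compound 1 likewise gives only a limit, > 4000 nM. So both measured values stand at limits, and no step between measured compounds can be sized from them. Compound 3 `COc1ccc(NC2=CC(=O)c3nc4n(c3C2=O)[C@H]2OC[C@@H](O)[C@H]2OC4)cc1` is not yet measured. The change from compound 2 to compound 3 is 4-methoxyphenyl in place of cyclohexyl on an amine nitrogen. The expectation rests on the two limits alone: compound 1, which also has an aromatic ring on the amine nitrogen, gives only the limit > 4000 nM. The step of a number no higher from compound 2 to compound 3 (the limit leaves the size open) is therefore expected to be none beyond the scatter. Compound 3 is expected to give about 8000 nM, within a range from 3000 nM to 30000 nM, and most likely again only a limit.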

Compound 3, half-maximal inhibitory concentration: 5420 nM
The estimate for compound 3 lay 1.5-fold (0.17 log units) above the measured number; measured number inside the range.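

Within the data shown here, compound 3 is the first compound here to give a real number rather than a limit: in this assay compound 3 gives 5420 nM. Putting 4-methoxyphenyl in place of cyclohexyl on the amine nitrogen gives an at least 1.4-fold lower number from compound 2 to compound 3 (0.16 log units; that floor lies within the scatter), so the change is not shown to strengthen inhibition, although a larger true effect is not ruled out. The step has only a floor and no exact size because compound 2 stands at a limit: the limit of > 8000 nM in this assay, at which 1 of the 3 values shown sits.

The compounds shown leave open whether the methoxy group itself matters on this aromatic ring, and a 4-chlorophenyl or a 4-carboxyphenyl group at the same amine nitrogen would help to test that. They also leave open whether a benzyl group or a longer chain there would move the number beyond the usual scatter.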